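The source may report more compounds than this note shows. Statements on the series, on what has been measured and on what is new or still open speak of the compounds shown alone.

Measured in a functional assay on MDA-MB-231 cells (Homo sapiens) for antiproliferative activity, read by MTT assay, with a stated time of 48 h; a lower number here means a stronger inhibitor, a higher number a weaker inhibitor:
- compound 1 `COC(=O)/C(=C/c1ccccc1)CN1C(=O)[C@@H](OC)[C@H]1c1cccc(Cl)c1`: no result reported
- compound 2 `CCOC(=O)/C(=C/c1ccccc1)CN1C(=O)[C@@H](OC)[C@H]1c1ccccc1Br`: 6860 nM

From the compounds shown here alone, compound 1 has no number in this test, so its standing is unknown and nothing can be read from it directly. The next compound to be measured is compound 3 `COC(=O)/C(=C/c1ccccc1)CN1C(=O)[C@@H](OC)[C@H]1c1cccc([N+](=O)[O-])c1`. The structural change is nitro in place of chloro on an aromatic carbon, or 3-chlorophenyl to 3-nitrophenyl. Within the data shown here, no measured pair shows what such a swap does. The expectation for this step in this assay is therefore no change beyond the scatter, and no direction can be favoured. Among the measured compounds shown here, the only anchor is compound 2, at 6860 nM, a single value that leaves the forecast loose. For compound 3 the estimated value is 7000 nM, with an expected range of 1500 nM to 30000 nM.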

Compound 3, half-maximal inhibitory concentration: 14400 nM
For compound 3 the middle estimate is 2.1-fold (0.31 log units) below the measured one; measured number inside the range.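

No step can be read here: compound 1 has no number to set against compound 3, and compound 2 differs from compound 3 in more than one place. From the compounds shown here alone, what nitro in place of chloro does to activity stays open. Nothing at hand offers an explanation for the value of compound 3.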